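This account rests on a few compounds, and the source may have more. Where it says the series, first, only, none or still open, it means among the compounds named here.

Working notes on the series. In a functional assay on A20 cells (Mus musculus) for inhibition, with stated times of 1 h, 16 h and 24 h (a higher number here means a weaker inhibitor, a lower number a stronger inhibitor), compound 1 `N#CC1(NC(=O)[C@@H]2C[C@@H](S(=O)(=O)c3ccccc3)C[C@H]2C(=O)N2CCCCC2)CC1` gives 5 nM and compound 2 `N#CC1(NC(=O)[C@@H]2C[C@@H](S(=O)(=O)c3ccccc3)CN2C(=O)c2ccccc2)CC1` gives 217 nM as the higher of the two numbers, a gap beyond the scatter. Compound 2 is therefore the weaker inhibitor of this pair. Compound 3 `N#CC1(NC(=O)[C@@H]2C[C@@H](S(=O)(=O)c3ccccc3Cl)CN2C(=O)c2ccccc2)CC1` matches compound 2 except that phenylsulfonyl becomes (2-chlorophenyl)sulfonyl: chloro in place of hydrogen on an aromatic carbon with chloro in place of hydrogen on an aromatic carbon, ortho to a large group. Within the data shown here, no measured pair shows the effect of this change, so the expectation is tentative. In this assay a moderate move toward a lower number is expected, although a result within the scatter remains possible. The estimated change is a 3.1-fold lower number from compound 2 to compound 3 (0.49 log units; beyond the scatter) on this reading. Compound 3 is estimated at 70 nM with an expected range from 15 nM to 300 nM for the half-maximal inhibitory concentration.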

Compound 3, half-maximal inhibitory concentration: 15 nM
Estimate against measurement, compound 3: 4.7-fold (0.67 log units) above; low and high end bracket the measured number.
By their numbers in this assay, from the lowest: compound 1; then compound 3; then compound 2.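

In this assay, among these compounds, chloro in place of hydrogen on an aromatic carbon, ortho to a large group, gives a 14-fold lower number from compound 2 to compound 3 (1.16 log units; beyond the scatter) as the first measured pair for this change, and the step is large. This place on the phenylsulfonyl group therefore responds strongly to the addition of a single chlorine, which compound 1 and compound 2 alone could not show. Nothing measured here accounts for the size of the step.

Going by these compounds, whether this gain is specific to chloro stays open, since fluoro, methyl or methoxy at the same place would be needed to tell chloro apart from other small groups. On these data alone, it is also open whether 2-chlorophenyl brings a similar step on the core of compound 1, and whether chloro elsewhere on the phenyl behaves the same way.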